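Compound 4: bromo in place of trifluoromethyl

The compounds below may be only part of what the source reports. "The series", "measured", "known", "first", "only" and "open" are said of these compounds alone.

In a functional assay on HepG2 cells (Homo sapiens) for cytotoxicity, read by MTT assay, with a stated time of 24 h (a lower number here means a stronger inhibitor, a higher number a weaker inhibitor), compound 3 `O=C1/C(=C/c2ccncc2)CN(S(=O)(=O)c2ccc(C(F)(F)F)cc2)C/C1=C\c1ccccc1C(F)(F)F` gives 3240 nM, within the scatter of compound 1 `O=C1/C(=C/c2cccnc2)CN(S(=O)(=O)c2ccc(Br)cc2)C/C1=C\c1ccccc1C(F)(F)F` at 2730 nM and of compound 2 `Cc1ccc(S(=O)(=O)N2C/C(=C\c3ccncc3)C(=O)/C(=C/c3ccccc3C(F)(F)F)C2)cc1` at 4640 nM. Compound 4 `O=C1/C(=C/c2ccncc2)CN(S(=O)(=O)c2ccc(Br)cc2)C/C1=C\c1ccccc1C(F)(F)F` has bromo in place of trifluoromethyl on an aromatic carbon, para to a large group (bromo in place of trifluoromethyl on an aromatic carbon). For the measured compounds named here, the one measured step at this place, trifluoromethyl in place of methyl, is a 1.4-fold lower number from compound 2 to compound 3 (0.16 log units; within the scatter), and it stays within the scatter. Compound 1 also carries 4-bromophenyl and gives 2730 nM. No change beyond the scatter is therefore expected in this assay. The expected step, within the scatter, is a 1.1-fold lower number from compound 3 to compound 4 (0.03 log units; within the scatter). For compound 4 the estimate is 3000 nM, with an expected range of 1600 nM to 5600 nM.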

Compound 4, half-maximal inhibitory concentration: 14500 nM
For compound 4 the middle estimate is 4.8-fold (0.68 log units) below the measured one; the whole stated range lies below it.
By their numbers in this assay, from the lowest: compounds 1, 3 and 2 (each within the scatter of the next); then compound 4.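

In this assay, bromo at this position stands apart from methyl and trifluoromethyl (a 4.5-fold higher number from compound 3 to compound 4 (0.65 log units; beyond the scatter); a 3.1-fold higher number from compound 2 to compound 4 (0.49 log units; beyond the scatter)), although the step between those two groups stays within the scatter (a 1.4-fold lower number from compound 2 to compound 3 (0.16 log units; within the scatter)). With 4-bromophenyl held constant, the pyridine attachment also matters (a 5.3-fold higher number from compound 1 to compound 4 (0.73 log units; beyond the scatter)), so 4-bromophenyl alone does not set the number. No measured evidence accounts for either change. The compounds shown leave open whether chloro, methoxy or an amine at this place tracks bromo, and whether the pyridine step persists with methyl or trifluoromethyl.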